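Shortening the chain on the aromatic nitrogen of compound 2

The source may hold more compounds than are shown below. What is called first, only, known or untested is meant among the compounds shown, and "the series" means these compounds.

Measured so far:
compound 1, `COc1cc(Cc2nc3c(N)ncnc3n2CC2CCCO2)cc(OC)c1OC`, 91200 nM
compound 2, `COc1cc(Cc2nc3c(N)ncnc3n2CCCC(C)C)cc(OC)c1OC`, 69200 nM

Both compounds were tested in a functional assay on MCF7 cells (Homo sapiens) for antiproliferative activity; a higher number here means a weaker inhibitor, a lower number a stronger inhibitor. Among the measured compounds shown here, compound 2 has the lowest of the two numbers, but its only neighbour is compound 1, and the step of a 1.3-fold lower number from compound 1 to compound 2 (0.12 log units; within the scatter) is within the scatter, so the two cannot be ordered.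

Compound 3, `COc1cc(Cc2nc3c(N)ncnc3n2CC(C)C)cc(OC)c1OC`, has not been measured. It differs from compound 2 in one place: isopropyl in place of isopentyl on a saturated chain carbon bound to an aromatic nitrogen.

For the measured compounds named here, only one measured step touches the same position, the step from compound 1 to compound 2, which swapped one group for another on a saturated chain carbon bound to an aromatic nitrogen and gave a 1.3-fold lower number from compound 1 to compound 2 (0.12 log units; within the scatter). That step did not move the number beyond the scatter. The change to compound 3 again alters only this chain, and nothing in the data speaks for a shift in either direction, so the step of a 1.2-fold higher number from compound 2 to compound 3 (0.06 log units; within the scatter) is expected to stay within the scatter.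

Compound 3 is therefore estimated at 80000 nM, with a range from 35000 nM to 200000 nM.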

Compound 3, half-maximal inhibitory concentration: 97700 nM
The estimate for compound 3 lay 1.2-fold (0.09 log units) below the measured number; measured number inside the range.
By their numbers in this assay, from the lowest: compounds 2, 1 and 3 (each within the scatter of the next).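

In this assay, isopropyl in place of isopentyl on a saturated chain carbon bound to an aromatic nitrogen gives a 1.4-fold higher number from compound 2 to compound 3 (0.15 log units; within the scatter), so a chain of 3 heavy atoms and one of 5 heavy atoms cannot be told apart at this position. The earlier pair compared only oxolan-2-yl with isopentyl; now isopropyl in place of oxolan-2-yl gives a 1.1-fold higher number from compound 1 to compound 3 (0.03 log units; within the scatter), which shows that the ring-bearing group cannot be told apart from the shorter open chain either. With all three groups within the scatter of one another, no order can be drawn among them, and no measurement here offers a reason for this result.

The compounds shown leave open whether any group at this position can move the number beyond the scatter, a question that a longer chain such as octyl, a benzyl group, or a chain ending in an amine or a carboxylic acid could address. They also leave open how the number responds to changes elsewhere, since the rest of the structure is the same in all three compounds.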